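The source may hold more compounds than are shown below. What is called first, only, known or untested is meant among the compounds shown, and "the series" means these compounds.

Measured so far in a functional assay on Jurkat cells (Homo sapiens); on this read-out lower numbers stand for stronger inhibition and higher numbers for weaker inhibition:
- compound 1 `CC(C)[C@H](NC(=O)COc1cccc2ccccc12)C(=O)N[C@@H](CC(=O)O)C(=O)COc1cccc2ccccc12`: > 100000 nM (a limit)
- compound 2 `CC(C)[C@H](NC(=O)COc1cccc2ccccc12)C(=O)N[C@@H](CC(=O)O)C(=O)COc1ccccc1C(F)(F)F`: > 100000 nM (a limit)
- compound 3 `CC(C)[C@H](NC(=O)COc1cccc2ccccc12)C(=O)N[C@@H](CC(=O)O)C(=O)COc1ccc(F)cc1F`: 33200 nM (a number)

Among the compounds with values here, compound 3 is the only member of the series with a measured number (33200 nM). Compound 1 and compound 2 both rest at the limit of > 100000 nM in this assay, at which 2 of the 3 values shown sit.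

Compound 4 `CC(C)[C@H](NC(=O)COc1cccc2ccccc12)C(=O)N[C@@H](CC(=O)O)C(=O)COc1c(F)cccc1F` keeps the rest of compound 3 and alters a single group: 2,6-difluorophenyl in place of 2,4-difluorophenyl on an oxygen on a saturated carbon. The two fluorines stay on the ring, and 2,6-difluorophenyl takes the place of 2,4-difluorophenyl on an oxygen on a saturated carbon.

Two measured steps change the group at this same place: an at least 3.0-fold lower number from compound 1 to compound 3 (0.47 log units; beyond the scatter) and an at least 3.0-fold lower number from compound 2 to compound 3 (0.47 log units; beyond the scatter). Both show that this group can move the read-out, although neither can be sized exactly. The third step, a step that the two limits leave unreadable from compound 1 to compound 2, gives no usable size. Within the data shown here, no measured step compares two difluorophenyl groups, so the direction of the change remains uncertain, and a small change is the working expectation.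

The estimated step is a 1.3-fold lower number from compound 3 to compound 4 (0.12 log units; within the scatter). For compound 4 the expected value is 25000 nM, with an estimated range from 5000 nM to 100000 nM.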

Compound 4, half-maximal inhibitory concentration: 2040 nM
For compound 4 the middle estimate is 12-fold (1.09 log units) above the measured one; measured number below the stated range.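

In this assay, a 16-fold lower number from compound 3 to compound 4 (1.21 log units; beyond the scatter), although the two groups are 2,4-difluorophenyl and 2,6-difluorophenyl and the atoms are the same, so the arrangement of the two fluorines on this ring can by itself move the read-out by a large amount. The earlier compounds shown here showed that exchanging the whole group at this place can matter, but they gave no step of exact size, and none compared two arrangements of the same atoms. Compound 4 also gives an at least 49-fold lower number from compound 2 to compound 4 (1.69 log units; beyond the scatter) and an at least 49-fold lower number from compound 1 to compound 4 (1.69 log units; beyond the scatter), and both steps remain open-ended because compounds 1 and 2 give only a limit: the limit of > 100000 nM in this assay, at which 2 of the 4 values shown sit.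

What the compounds shown leave open is whether the arrangement in 2,6-difluorophenyl is what counts or whether a 2,6-dichlorophenyl or 2,6-dimethylphenyl group at the same place would give a number near that of compound 4, 2040 nM. They also do not show whether a single fluorine on the ring would suffice, or whether the step from 2,4-difluorophenyl to 2,6-difluorophenyl would keep its size on a changed core.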